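Trimming the Side Chain of Compound 1

This account rests on a few compounds, and the source may have more. Where it says the series, first, only, none or still open, it means among the compounds named here.

Going by the values given here, in a functional assay on SW480 cells (Homo sapiens) for antiproliferative activity, read by MTT assay, with a stated time of 48 h (a higher number here means a weaker inhibitor, a lower number a stronger inhibitor), compound 1 (`CCCC(CCO)n1cnc2c(Cl)nc(F)nc21`) gives 17200 nM and compound 2 (`CCCCCCCCCC(CCO)n1cnc2c(Cl)nc(F)nc21`) gives 12500 nM as its only neighbour, the two lying within the scatter of each other. Compound 3 (`OCCCn1cnc2c(Cl)nc(F)nc21`) has hydrogen in place of propyl on a saturated chain carbon bound to an aromatic nitrogen and a saturated chain carbon. Among the compounds with values here, the only measured step bearing on this is the addition of hexyl, a 1.4-fold lower number from compound 1 to compound 2 (0.14 log units; within the scatter) in size, and it adds to the chain without removing anything. An estimated 1.2-fold higher number from compound 1 to compound 3 (0.07 log units; within the scatter) is therefore expected, with nothing beyond the scatter. Compound 3 is expected at 20000 nM (estimated range 8000 nM to 50000 nM).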

Compound 3, half-maximal inhibitory concentration: 29700 nM
Compound 3: middle estimate off by 1.5-fold (0.17 log units), on the low side, within the range that was stated.
By their numbers in this assay, from the lowest: compounds 2, 1 and 3 (each within the scatter of the next, the first and the last beyond it).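

In this assay, taking propyl off this saturated chain carbon altogether, with hydrogen in its place, gives a 1.7-fold higher number from compound 1 to compound 3 (0.24 log units; within the scatter), so compound 1 does not depend measurably on propyl here. The two ends of the series do separate, though: compound 2 gives 12500 nM and compound 3 gives 29700 nM, a gap beyond the scatter. No evidence is available to explain this. The compounds shown leave open whether an amine or a carboxylic acid on this carbon would move the number beyond the scatter from compound 1.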